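A few compounds are considered here, and "the series" means these few. Any claim that something is new, unique, unknown or untested is made for them only; others in the source may bear on it.

Compound 1 `OCCNc1nccc2c1ncn2C1O[C@H](CO)[C@@H](O)[C@H]1O` gives 0% in a functional assay (Homo sapiens) for inhibition of Nucleic Acid, tested at 100 uM; on this read-out lower numbers stand for less inhibition and higher numbers for more inhibition at the one concentration tested (going by the name of the read-out).
Compound 2 `[N-]=[N+]=Nc1nccc2c1ncn2C1O[C@H](CO)[C@@H](O)[C@H]1O` gives 4% in this assay.
Compound 3 `OC[C@H]1OC(n2cnc3c(NCc4ccccc4)nccc32)[C@H](O)[C@@H]1O` gives 32% in this assay.

Compound 3 stands highest of the three, its steps to both others beyond the scatter. Compound 4 `CCCCCCNc1nccc2c1ncn2C1O[C@H](CO)[C@@H](O)[C@H]1O` differs from it by pentyl in place of phenyl on a saturated chain carbon bound to a nitrogen on an aromatic ring. Among the measured compounds shown here, two steps bear on this place: a number 32 percentage points higher from compound 1 to compound 3 (beyond the scatter) and a number 28 percentage points higher from compound 2 to compound 3 (beyond the scatter), both showing that a benzyl group there raises the number well beyond the scatter. Nothing measured shows a plain chain at this place, so how much of that gain survives when the ring leaves is uncertain. Compound 4 is expected to fall somewhat, with a number 14 percentage points lower from compound 3 to compound 4 (beyond the scatter). Compound 4 is therefore estimated at 18%, between 0% and 40%.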

Compound 4, a percentage reported as inhibition, at one concentration (the size of the read-out at that concentration, not a potency): 8%
Compound 4: middle estimate off by 10 percentage points, on the high side; low and high end bracket the measured number.
By their numbers in this assay, from the lowest: compounds 1, 2 and 4 (each within the scatter of the next); then compound 3.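

In this assay, the gain seen with benzylamino does not carry over to a plain chain of carbon atoms: a number 24 percentage points lower from compound 3 to compound 4 (beyond the scatter). Hexylamino also stays level with the azido and hydroxyethylamino groups, with a number 4 percentage points higher from compound 2 to compound 4 (within the scatter) and a number 8 percentage points higher from compound 1 to compound 4 (within the scatter), so among these compounds only the benzyl group stands apart at this place. Nothing at hand explains this difference. Open, as far as these compounds go, is whether cyclohexylmethyl, a saturated ring, would keep the gain, or whether it needs the aromatic ring. Also open, from the compounds shown here alone, is how a pyridylmethyl or phenethyl group would read here.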